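Replacing cyano with trifluoromethoxy in compound 1

This account rests on a few compounds, and the source may have more. Where it says the series, first, only, none or still open, it means among the compounds named here.

The series is read in a functional assay on HCT-116 cells (Homo sapiens) for antiproliferative activity, read by WST assay, with a stated time of 72 h; on this read-out lower numbers stand for stronger inhibition of growth and higher numbers for weaker inhibition of growth. Here compound 1 (`N#Cc1ccc(CN[C@H]2[C@@H]3CN(c4ncc(C(=O)NO)cn4)C[C@@H]32)cc1`) gives 270 nM. Compound 2 (`O=C(NO)c1cnc(N2C[C@@H]3[C@H](C2)[C@H]3NS(=O)(=O)c2ccc3ccccc3c2)nc1`) gives 440 nM, and compound 3 (`O=C(NO)c1cnc(N2C[C@@H]3[C@H](C2)[C@H]3NC(=O)c2ccc3ccccc3c2)nc1`) gives 410 nM. Compound 1 therefore stands within the scatter of both other compounds, and these three numbers do not separate it from them.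

Compound 4 (`O=C(NO)c1cnc(N2C[C@@H]3[C@H](C2)[C@H]3NCc2ccc(OC(F)(F)F)cc2)nc1`) keeps the core of compound 1 and carries trifluoromethoxy in place of cyano on an aromatic carbon, para to a large group: trifluoromethoxy in place of cyano on an aromatic carbon.

For the measured compounds named here, no measured pair differs in one place only, so no direct guide to this change exists. Compounds 1, 2 and 3 carry different groups on the shared core, yet their numbers stay within the scatter of one another. In this assay, no change beyond the scatter is therefore expected. The expected step is a 1.1-fold higher number from compound 1 to compound 4 (0.05 log units; within the scatter). The estimated value for compound 4 is 300 nM, with an expected range of 120 nM to 750 nM.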

Compound 4, concentration for 50% growth inhibition: 120 nM
Beside the measured number, compound 4's estimate is 2.5-fold (0.40 log units) above it; the measured number falls inside the stated range.
By their numbers in this assay, from the lowest: compound 4; then compounds 1, 3 and 2 (each within the scatter of the next).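

In this assay, the substituent on this aromatic carbon, para to a large group, does affect the read-out: trifluoromethoxy in place of cyano gives a 2.3-fold lower number from compound 1 to compound 4 (0.35 log units; beyond the scatter). This modest step is the only one in the series that can be read at a single place, whereas compound 1, compound 2 and compound 3 differ from one another in more than one place. Trifluoromethoxy, the larger of the two groups by heavy atoms, is therefore accepted on this carbon with stronger inhibition of growth.

On these data alone, whether a methoxy group, a chlorine atom or a trifluoromethyl group on the same carbon would give a similar number stays open, as does the effect of an amine or a carboxylic acid there. No supporting data bear on why the number moves with this change.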